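The source may report more compounds than this note shows. Statements on the series, on what has been measured and on what is new or still open speak of the compounds shown alone.

Going by the values given here, compound 1 `O=C(Nc1ccc(-n2ncc3c(F)cccc32)cc1)Nc1ccc(Cl)c(C(F)(F)F)c1` gives 16000 nM in a functional assay on Bel-7402 cells (Homo sapiens) for cytotoxicity, read by MTT assay, with a stated time of 72 h (on this read-out lower numbers stand for stronger inhibition and higher numbers for weaker inhibition), the highest of the three numbers measured so far. Compound 2 `CNc1cccc2c1cnn2-c1ccc(NC(=O)Nc2ccc(Cl)c(C(F)(F)F)c2)cc1` gives 5000 nM in this assay, and compound 3 `COc1cccc2c1cnn2-c1ccc(NC(=O)Nc2ccc(Cl)c(C(F)(F)F)c2)cc1` gives 2900 nM. The two steps away from compound 1 are modest: a 3.2-fold lower number from compound 1 to compound 2 (0.51 log units; beyond the scatter) and a 5.5-fold lower number from compound 1 to compound 3 (0.74 log units; beyond the scatter). The step of a 1.7-fold lower number from compound 2 to compound 3 (0.24 log units; within the scatter) lies within the scatter.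

Compound 4 `O=C(Nc1ccc(-n2ncc3cnccc32)cc1)Nc1ccc(Cl)c(C(F)(F)F)c1` differs from compound 1 in one place: a group of 9 heavy atoms (6 carbon, 3 nitrogen; one five-membered aromatic ring with 2 hetero atoms, one six-membered aromatic ring with 1 hetero atom) in place of a group of 10 heavy atoms (7 carbon, 2 nitrogen, 1 fluorine; one five-membered aromatic ring with 2 hetero atoms, one six-membered aromatic ring of carbon only), on an aromatic carbon. Both measured steps from compound 1 exchange only the fluoro substituent on the six-membered carbon ring of the bicyclic group, leaving that ring intact; neither exchanges the ring itself for one holding a nitrogen, as here. They therefore bear on this change only loosely, showing that altering this part of compound 1 gave modestly lower numbers in this assay each time. On that basis a step of at most similar size, towards a lower number, is expected for compound 4, a 2.0-fold lower number from compound 1 to compound 4 (0.30 log units; within the scatter), with wide uncertainty. Compound 4 is therefore estimated at 8000 nM, within a range of 2500 nM to 25000 nM.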

Compound 4, half-maximal inhibitory concentration: 2700 nM
Beside the measured number, compound 4's estimate is 3.0-fold (0.47 log units) above it; the range from low to high includes it.
By their numbers in this assay, from the lowest: compounds 4, 3 and 2 (each within the scatter of the next); then compound 1.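

The ring itself can be changed at this position, not just the fluoro substituent: a 5.9-fold lower number from compound 1 to compound 4 (0.77 log units; beyond the scatter), in this assay, with a six-membered aromatic ring holding one hetero atom replacing the carbon-only ring of the 4-fluoro-1H-indazol-1-yl group. The lower number therefore does not depend on a methylamino or methoxy substituent taking the place of fluoro, as compound 4 carries neither. No measurement at hand accounts for this step.

Going by these compounds, the step combines loss of the fluoro group with the entry of the ring nitrogen, so the share of each stays open; an unsubstituted 1H-indazol-1-yl group would separate them. On these data alone, whether the nitrogen-containing ring tolerates a substituent such as an amine or a carboxylic acid also remains open.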